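Dichlorophenyl Replaces Methylphenyl on a Biaryl Chemokine Ligand

This account rests on a few compounds, and the source may have more. Where it says the series, first, only, none or still open, it means among the compounds named here.

The compounds share a bicyclic tertiary amine core, seen in its simplest form in compound 1 `CN(CC1=CC[C@H]2C[C@@H]1C2(C)C)Cc1ccc(Cl)cc1`, which carries a chloro on the aromatic ring. In an assay on HEK293 cells for displacement of a labelled ligand from C-X-C chemokine receptor type 3 (Homo sapiens) (a lower number here means a stronger inhibitor, a higher number a weaker inhibitor), compound 1 gives 2510 nM. Compound 2 `CC(=O)c1cccc(-c2ccc(CN(C)CC3=CC[C@H]4C[C@@H]3C4(C)C)cc2)c1` bears a 3-acetylphenyl in place of that chloro. In this assay compound 2 gives only a limit, > 316 nM. Compound 3 `Cc1cccc(-c2ccc(CN(C)CC3=CC[C@H]4C[C@@H]3C4(C)C)cc2)c1` bears a 3-methylphenyl at the same position. In this assay compound 3 likewise gives only a limit, > 316 nM. As a consequence a step that the limit leaves unreadable from compound 1 to compound 2 and a step that the limit leaves unreadable from compound 1 to compound 3 cannot be read, and neither can a step that the two limits leave unreadable from compound 2 to compound 3, because of the limit of > 316 nM in this assay, at which 2 of the 3 values shown sit. Going by the values given here, compound 3 therefore stands at the limit of this assay, alongside compound 2, while compound 1 is the only compound of the three with a number.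

Compound 4 `CN(CC1=CC[C@H]2C[C@@H]1C2(C)C)Cc1ccc(-c2cc(Cl)cc(Cl)c2)cc1` differs from compound 3 by 3,5-dichlorophenyl in place of 3-methylphenyl on an aromatic carbon. Among the compounds with values here, no measured step bears directly on this exchange, and the three steps that exist are all unreadable, so they offer neither a direction nor a size. Compound 4 is therefore expected to remain close to the limit, with a step that the limit leaves unreadable from compound 3 to compound 4 expected to be small. In this assay compound 4 is estimated at 1000 nM, with a range from 300 nM to 5000 nM.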

Compound 4, inhibition constant: > 316 nM
Compound 4 ended at the assay's limit; the forecaster's own chance of this, stated with the estimate: 65%; the middle value lies beyond the limit too.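

In this assay compound 4 gives only a limit, > 316 nM. None of the steps to compound 4 from compound 1, compound 2 or compound 3 can be read, for one reason: the limit of > 316 nM in this assay, at which 3 of the 4 values shown sit.

The compounds shown leave open whether compound 2, compound 3 and compound 4 differ from one another at all, and how each compares with compound 1.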